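The source may hold more compounds than are shown below. What is called first, only, known or untested is meant among the compounds shown, and "the series" means these compounds.

In a functional assay on MCF7 cells (Homo sapiens) for cytotoxicity, read by MTT assay, with a stated time of 96 h (a higher number here means a weaker inhibitor, a lower number a stronger inhibitor), compound 1 `COc1cc(C(=O)c2cn(-c3cccc(N)c3)cc2-c2ccccc2F)cc(OC)c1OC` gives 17 nM and compound 2 `COc1cc(C(=O)c2cn(-c3ccc(C)cc3)cc2-c2ccccc2F)cc(OC)c1OC` gives 44 nM as the higher, weaker number of the pair. Compound 3 `COc1cc(C(=O)c2cn(-c3ccc(C)cc3)cc2-c2ccc(N)cc2)cc(OC)c1OC` keeps the 4-methylphenyl group of compound 2 and has 4-aminophenyl in place of 2-fluorophenyl on an aromatic carbon. Among the measured compounds shown here, the only measured step (a 2.6-fold higher number from compound 1 to compound 2 (0.41 log units; beyond the scatter)) lies on the aromatic nitrogen, so no measured step covers this place directly. That modest step, beyond the scatter, gives only a rough size for one aryl group replacing another. The data do not fix the direction here, but a modest step towards a higher number is expected in this assay as a tentative call. The estimated change is a 2.3-fold higher number from compound 2 to compound 3 (0.36 log units; beyond the scatter) on that reading. For compound 3 the expected value is 100 nM with an estimated range of 20 nM to 500 nM at this stage.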

Compound 3, half-maximal inhibitory concentration: 6 nM
Compound 3: middle estimate off by 17-fold (1.22 log units), on the high side; the whole stated range lies above it.
By their numbers in this assay, from the lowest: compound 3; then compound 1; then compound 2.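

In this assay, the group on this aromatic carbon of the five-membered aromatic ring, two ring bonds from the ring nitrogen, clearly affects the read-out: 4-aminophenyl in place of 2-fluorophenyl gives a 7.3-fold lower number from compound 2 to compound 3 (0.87 log units; beyond the scatter). The exchange keeps the count of heavy atoms but replaces fluorine with an amine, adding a hydrogen-bond donor and a hydrogen-bond acceptor, and the substituent name changes from 2- to 4-, so this single step combines more than one change. Nothing available here bears on the origin of the lower number.

The compounds shown leave open whether the amine or the loss of the fluorine carries the step. They also leave open how a hydroxyl, a methoxy group or a dimethylamino group would read in place of that amine.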